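From 1-benzofuran-2-yl to 1,3-thiazol-2-yl on a shared core

This account rests on a few compounds, and the source may have more. Where it says the series, first, only, none or still open, it means among the compounds named here.

Of the compounds shown here, three built on one shared core have been tested in a functional assay on CCRF-CEM cells (Homo sapiens) for inhibition; a lower number here means a stronger inhibitor, a higher number a weaker inhibitor. Compound 1 `Cn1nccc1-c1ncnc2c1ncn2C1O[C@H](CO)[C@@H](O)[C@H]1O` is reported as "not active" (no number reported), without a number. Compound 2 `OC[C@H]1OC(n2cnc3c(-c4ccc(O)cc4)ncnc32)[C@H](O)[C@@H]1O` gives 1250 nM. Compound 3 `OC[C@H]1OC(n2cnc3c(-c4cc5ccccc5o4)ncnc32)[C@H](O)[C@@H]1O` gives 15000 nM, the higher of the two numbers, which makes it the weaker inhibitor of that pair.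

The untested compound 4 `OC[C@H]1OC(n2cnc3c(-c4nccs4)ncnc32)[C@H](O)[C@@H]1O` keeps the core and changes one group: 1,3-thiazol-2-yl in place of 1-benzofuran-2-yl on an aromatic carbon. Here 1,3-thiazol-2-yl comes in place of 1-benzofuran-2-yl on an aromatic carbon.

For the measured compounds named here, only one measured step bears on this change, and it involves the same place on the core: a 12-fold higher number from compound 2 to compound 3 (1.08 log units; beyond the scatter). That large step shows that the group here can shift the number a long way, but it says nothing about 1,3-thiazol-2-yl itself. Compound 1 adds a caution, since it gave no number at all.

With compound 3 at 15000 nM, the top of the measured numbers, a move downward seems likelier than a move upward. The expected change is a 3.0-fold lower number from compound 3 to compound 4 (0.48 log units; beyond the scatter), a moderate drop that is far from certain. For compound 4 the estimate is 5000 nM, with an expected range from 800 nM to 30000 nM.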

Compound 4, half-maximal inhibitory concentration: 2730 nM
Compound 4: middle estimate off by 1.8-fold (0.26 log units), on the high side, and the stated range covers the measured number.
By their numbers in this assay, from the lowest: compound 2; then compound 4; then compound 3.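

In this assay, putting 1,3-thiazol-2-yl in place of 1-benzofuran-2-yl on this aromatic carbon gives a 5.5-fold lower number from compound 3 to compound 4 (0.74 log units; beyond the scatter) and so shows that the number at this position can also fall when a group changes, here with a single five-membered aromatic ring holding 2 hetero atoms in place of a fused pair of aromatic rings. The same 1,3-thiazol-2-yl set against 4-hydroxyphenyl gives a 2.2-fold higher number from compound 2 to compound 4 (0.34 log units; beyond the scatter) and so leaves compound 2 with the lowest of the three numbers, while compound 4 sits between the other two and much closer to compound 2 than to compound 3. No measurement shown here explains why these groups rank in this order.

For the compounds shown here, compound 1 is reported as "not active" (no number reported) and so offers no step that can be read, which leaves unclear how a second five-membered aromatic ring with a different set of hetero atoms would compare with 1,3-thiazol-2-yl. The compounds shown also leave open whether the hydroxyl on the phenyl ring of compound 2 matters at all, and how a plain phenyl, or a phenyl carrying an amine or a carboxylic acid, would behave on this carbon.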